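Triazole series at somatostatin receptor type 2: chain homologation

This account rests on a few compounds, and the source may have more. Where it says the series, first, only, none or still open, it means among the compounds named here.

Measured so far:
compound 1 `Clc1ccc(Cn2c(CCc3c[nH]cn3)nnc2Cc2c[nH]c3ccccc23)cc1Cl`: > 10000 nM
compound 2 `c1ccc(Cn2c(CCc3c[nH]c4ccccc34)nnc2C2CCNCC2)cc1`: > 10000 nM

Both measured compounds were tested in an assay on cells for displacement of a labelled ligand from somatostatin receptor type 2 (Homo sapiens), with a stated time of 90 min; on this read-out lower numbers stand for stronger inhibition and higher numbers for weaker inhibition. For compound 1 the value > 10000 nM is a limit of the assay, not a number. For compound 2 the value > 10000 nM is likewise a limit. Compound 1 therefore stands nowhere in particular on a scale: it sits at the limit of > 10000 nM in this assay, at which 2 of the 2 values shown sit, and no ranking between the two compounds can be read from what is shown. Within the data shown here, no step between measured compounds is available for the series.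

The next compound, compound 3 `Clc1ccc(Cn2c(CCc3c[nH]cn3)nnc2CCc2c[nH]c3ccccc23)cc1Cl`, differs from compound 1 in one place: (1H-indol-3-yl)methyl in place of 1H-indol-3-yl on a saturated chain carbon bound to an aromatic carbon. No measured step speaks to this change, and no cause can be given from the data shown. Because compound 1 sits at the limit of > 10000 nM in this assay, at which 2 of the 2 values shown sit, no shift beyond the scatter is expected in this assay for the step that the limit leaves unreadable from compound 1 to compound 3, and compound 3 is expected most likely to return a limit again. The estimate for compound 3 is 15000 nM, with a range from 3000 nM to 60000 nM.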

Compound 3, inhibition constant: > 10000 nM
Compound 3: a limit, no number; the forecaster's own chance of this, stated with the estimate: 75%; the middle value does not contradict the limit.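

In this assay compound 3 gives > 10000 nM as a limit of the assay and not a number. Compound 1 also stands at a limit, and no new step can be read from compound 1 to compound 3. The compounds shown leave open whether (1H-indol-3-yl)methyl in place of 1H-indol-3-yl changes the inhibition constant at all.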